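Swapping Methoxy for Chloro on a Thiourea

The source may hold more compounds than are shown below. What is called first, only, known or untested is meant among the compounds shown, and "the series" means these compounds.

Compound 1 `COc1ccc(NC(=S)Nc2nc[nH]n2)cc1` was tested in an ADME assay on MT4 cells (Homo sapiens) for cytotoxicity, read by MTT assay, with a stated time of 96 h; a lower number here means that less compound is tolerated, a higher number that more compound is tolerated. In this assay compound 1 gives > 100000 nM, which is a limit of the assay rather than a number. Compound 2 `S=C(Nc1nc[nH]n1)Nc1ccccc1Br` also sits at a limit, giving > 100000 nM in this assay. Among the measured compounds shown here, compound 3 `Nc1ncnn1/C(S)=N/Cc1ccccc1` is the one compound with a number, and in this assay compound 3 gives 7400 nM. Compound 1 thus stands together with compound 2 at the limit of > 100000 nM in this assay, at which 2 of the 3 values shown sit. Compound 4 `S=C(Nc1ccc(Cl)cc1)Nc1nc[nH]n1` differs from compound 1 in one place: chloro in place of methoxy on an aromatic carbon. For the measured compounds named here, no measured pair shows this change, so its size is not known from the data. The step expected in this assay is a number no higher from compound 1 to compound 4 (the limit leaves the size open), that is, none beyond the scatter. Compound 4 is therefore expected to give about 100000 nM in this assay, within a range from 30000 nM to 300000 nM.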

Compound 4, half-maximal cytotoxic concentration: 47000 nM
Beside the measured number, compound 4's estimate is 2.1-fold (0.33 log units) above it, and the stated range covers the measured number.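

Chloro in place of methoxy on this aromatic carbon brings an at least 2.1-fold lower number from compound 1 to compound 4 (0.32 log units; beyond the scatter) in this assay, so less compound is tolerated with chloro there. The group at this position can therefore move the read-out within the range the assay can measure. The full size of the step stays unknown because compound 1 sits at a limit and not at a number: the limit of > 100000 nM in this assay, at which 2 of the 4 values shown sit.

From the compounds shown here alone, whether an amine, a methyl or a carboxylic acid at this position would shift the number as well stays open. Also open, going by these compounds, is whether chloro elsewhere on the ring would do the same.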